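Moving Two Chlorines on a Dopamine Receptor Agonist

The source may hold more compounds than are shown below. What is called first, only, known or untested is meant among the compounds shown, and "the series" means these compounds.

Measured compounds:
compound 1, `O=C(CN1CCC(c2cccc[n+]2[O-])CC1)Nc1ccc(F)cc1F`: 103 nM
compound 2, `O=C(CN1CCC(c2cccc[n+]2[O-])CC1)Nc1cc(Cl)cc(Cl)c1`: 160 nM

Both compounds share one core and differ only in the aromatic group on the amide-type nitrogen. In a functional assay on HEK293 cells for agonist activity at D(4) dopamine receptor (Homo sapiens), read by FLIPR (on this read-out higher numbers stand for an effect only at larger amounts of compound and lower numbers for an effect already at smaller amounts), compound 1 gives 103 nM. In the same assay compound 2 gives 160 nM. The step of a 1.6-fold higher number from compound 1 to compound 2 (0.19 log units; within the scatter) is within the scatter, so the two numbers cannot be told apart with confidence. Of the two numbers shown, compound 2 has the larger one, and its nearest neighbour is compound 1, with the gap between them lying within the scatter.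

Compound 3, `O=C(CN1CCC(c2cccc[n+]2[O-])CC1)Nc1cccc(Cl)c1Cl`, is not yet measured. It differs from compound 2 by 2,3-dichlorophenyl in place of 3,5-dichlorophenyl on an amide-type nitrogen; the two have the same atoms, joined differently. Going by the values given here, only one measured step bears on changing the aromatic group at this position, a 1.6-fold higher number from compound 1 to compound 2 (0.19 log units; within the scatter), and it was within the scatter, so nothing measured here points to a change in either direction. The expected step for compound 3 is therefore no change at the digits printed from compound 2 to compound 3 (within the scatter), that is, none beyond the scatter. Compound 3 is estimated at 160 nM in this assay, with a range from 60 nM to 450 nM.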

Compound 3, half-maximal effective concentration: 180 nM
Beside the measured number, compound 3's estimate is 1.1-fold (0.05 log units) below it; the range from low to high includes it.
By their numbers in this assay, from the lowest: compounds 1, 2 and 3 (each within the scatter of the next).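

In this assay, moving the two chlorines from the 3,5-dichlorophenyl to the 2,3-dichlorophenyl arrangement gives a 1.1-fold higher number from compound 2 to compound 3 (0.05 log units; within the scatter) and stays within the scatter, while exchanging the 2,4-difluorophenyl for the 2,3-dichlorophenyl gives a 1.7-fold higher number from compound 1 to compound 3 (0.24 log units; within the scatter) and also stays within the scatter. Going by these compounds alone, the earlier step altered both the halogen and where it sat, whereas this new step keeps the same atoms and alters only how they are joined, so it is the first to isolate the placement of the chlorines, and for these two arrangements the numbers cannot be told apart. The data shown offer no evidence on what lies behind this closeness.

From the compounds shown here alone, all three compounds carry two halogens on the aromatic group, so it remains open how this position would respond to a plain phenyl ring, a single chlorine, or a different kind of group such as a methoxy group, an amine or a carboxylic acid. Going by these compounds, it is also open whether the same closeness would hold with larger groups here, such as trifluoromethyl, or with other chlorine arrangements.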